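The compounds below may be only part of what the source reports. "The series", "measured", "known", "first", "only" and "open" are said of these compounds alone.

Measured compounds in a toxicity assay on THP-1 cells (Homo sapiens) for inhibition; on this read-out lower numbers stand for higher toxicity in this test and higher numbers for lower toxicity in this test:
- compound 1 `Cn1c(-c2ccccc2)cnc1NC(=O)c1cc(-c2ccccn2)[nH]n1` gives > 50000 nM, which is a limit of the assay and not a number.
- compound 2 `COc1ccc(C(=O)Nc2ncc(-c3ccc(OC)cc3)n2C)cc1` gives > 100000 nM, again a limit of the assay rather than a measured number.

Compound 2 stands at the limit of > 100000 nM in this assay, at which 1 of the 2 values shown sits, so no numeric reading is available for it. Compound 1 stands at the limit of > 50000 nM in this assay, at which 1 of the 2 values shown sits. Both values shown are limits, so the two compounds cannot be set in any order against each other, and neither can be called more or less toxic than the other. Within the data shown here, no step between two measured compounds is available.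

Compound 3 `COc1ccc(-c2cnc(NC(=O)c3ccno3)n2C)cc1` is the next compound, not yet measured. Its difference from compound 2: 1,2-oxazol-5-yl in place of 4-methoxyphenyl on a carbonyl carbon. Among the measured compounds shown here, with no measured step to lean on, the expectation rests only on where compound 2 stands: the step of a number no higher from compound 2 to compound 3 (the limit leaves the size open) is expected to be none beyond the scatter, with the result most likely again reported only as a limit. Compound 3 is therefore estimated at 100000 nM, within 30000 nM to 300000 nM.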

Compound 3, half-maximal cytotoxic concentration: > 100000 nM
Compound 3 gave a limit, no number; the forecaster's own chance of this, stated with the estimate: 80%; the middle value lies on the limit itself.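

In this assay no step can be read between compound 2 and compound 3; both values are limits of the assay and not numbers. The compounds shown leave open whether any of them reaches a numeric reading in this assay, and how 1,2-oxazol-5-yl and 4-methoxyphenyl on a carbonyl carbon compare there.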